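Ethoxy for phenylsulfanyl on the fused core: expected potency

The source may hold more compounds than are shown below. What is called first, only, known or untested is meant among the compounds shown, and "the series" means these compounds.

Compounds with results so far:
compound 1 `c1ccc(Sc2nn3cc(-c4cc5ccccc5o4)nc3s2)cc1`: "not determined" (no result reported)
compound 2 `CCSc1nn2cc(-c3cc4ccccc4o3)nc2s1`: "not determined" (no result reported)
compound 3 `COc1nn2cc(-c3cc4c(OC)cccc4o3)nc2s1`: 350 nM

In an assay for antagonist activity at proteinase-activated receptor 4 (Homo sapiens), with stated times of 5 min, 50 s and 15 min, in the presence of a further agent that is not named here (on this read-out higher numbers stand for weaker inhibition and lower numbers for stronger inhibition), compound 1 gives "not determined" (no result reported) and so has no number to stand on; compound 2 likewise gives "not determined" (no result reported). Among the compounds with values here, the only number in this assay comes from compound 3, which gives 350 nM and also carries a methoxy on its benzofuran, so it is not a one-place comparator for compound 4.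

Compound 4 `CCOc1nn2cc(-c3cc4ccccc4o3)nc2s1` is to be measured in this assay. It differs from compound 1 by ethoxy in place of phenylsulfanyl on an aromatic carbon, in words ethoxy in place of phenylsulfanyl on an aromatic carbon. Within the data shown here, no comparable step between measured compounds exists, so no direction can be read off the series.

Compound 4 is estimated at 400 nM, expected within 100 nM to 1600 nM.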

Compound 4, half-maximal inhibitory concentration: 2100 nM
Compound 4: middle estimate off by 5.3-fold (0.72 log units), on the low side, and the stated range ends below it.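

In this assay, within the data shown here, compound 4 gives 2100 nM, but no step from compound 1 to compound 4 can be read. Going by these compounds, the effect of ethoxy in place of phenylsulfanyl on potency stays open. No evidence bears on this result.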